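Ester in place of ether on the shared core

The source may hold more compounds than are shown below. What is called first, only, known or untested is meant among the compounds shown, and "the series" means these compounds.

Of the compounds shown here, three of one series have been measured so far. Compound 1 `COc1cccc2c(=O)cc(/C=C/[S+](C)[O-])oc12`, compound 2 `CCOc1ccc2oc(/C=C/[S+](C)[O-])cc(=O)c2c1` and compound 3 `Cc1c(/C=C/[S+](C)[O-])oc2ccccc2c1=O` all carry the same core and vary only in the substituent on the aromatic part. In a functional assay on A549 cells (Homo sapiens) for cytotoxicity, with a stated time of 48 h (a lower number here means a stronger inhibitor, a higher number a weaker inhibitor), compound 1 gives 2200 nM. In this assay compound 2 gives 1500 nM and compound 3 gives 1500 nM. The three numbers lie close together: compound 2 and compound 3 agree at the digits shown, and the gap from compound 2 to compound 1 stays within the usual scatter, so no order among the three can be read from these values.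

Compound 4 `CCC(=O)Oc1ccc2oc(/C=C/[S+](C)[O-])cc(=O)c2c1` has not yet been measured in this assay. It is related to compound 2 by a single change: propanoyl in place of ethyl on an oxygen on an aromatic ring. The ethoxy of compound 2 thus becomes a propanoyloxy in compound 4. For the measured compounds named here, no measured pair shows what such a change does, so there is no step to lean on.

Given that the three measured numbers sit within the scatter of one another, the expected step from compound 2 to compound 4 is a 1.2-fold higher number from compound 2 to compound 4 (0.08 log units; within the scatter), that is, no shift beyond the scatter in either direction. Compound 4 is therefore expected at 1800 nM, with a range from 700 nM to 4500 nM.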

Compound 4, half-maximal inhibitory concentration: 2400 nM
Compound 4: the middle estimate sits 1.3-fold (0.12 log units) below what was measured; the range from low to high includes it.
By their numbers in this assay, from the lowest: compounds 2, 3, 1 and 4 (each within the scatter of the next).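

In this assay, for the compounds shown here, propanoyl in place of ethyl on an oxygen on an aromatic ring gives a 1.6-fold higher number from compound 2 to compound 4 (0.20 log units; within the scatter) and so provides the first step that can be read in one place. Ethoxy to propanoyloxy brings in a carbonyl and a larger group on this oxygen, yet the step stays within the scatter, so this change leaves the cytotoxicity read-out without a detectable shift and compound 2 and compound 4 cannot be placed in any order. Nothing available on these compounds accounts for this result.

On these data alone, a single step at this oxygen cannot show whether the position tolerates change in general, so what a free hydroxyl, an amine-bearing chain such as 2-aminoethyl or a carboxylic acid such as carboxymethyl would do here stays open. Equally open, as far as these compounds go, is whether a longer chain, such as hexanoyl or octyl, would move the number beyond the scatter in either direction.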